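Cytotoxicity notes: cyano to chloro swap on the benzyl

The source may hold more compounds than are shown below. What is called first, only, known or untested is meant among the compounds shown, and "the series" means these compounds.

Compound 1 `N#Cc1ccccc1CN1C(=O)N(Cc2cccc(F)c2)S(=O)(=O)n2cccc21` was run in an ADME assay on MT4 cells (Homo sapiens) for cytotoxicity, read by MTT assay, with a stated time of 5 days; on this read-out higher numbers stand for lower toxicity in this test and lower numbers for higher toxicity in this test. Compound 1 gives only a limit there, > 305000 nM. Compound 2 `N#Cc1ccccc1CN1C(=O)N(Cc2cccc(Cl)c2)S(=O)(=O)n2cccc21` likewise gives only a limit, > 293000 nM. Compound 2 differs from compound 1 by chloro in place of fluoro on an aromatic carbon, and a step that the two limits leave unreadable from compound 1 to compound 2 between them, as both readings sit at limits (the limit of > 305000 nM in this assay, at which 1 of the 2 values shown sits; (the limit of > 293000 nM in this assay, at which 1 of the 2 values shown sits)). Among the measured compounds shown here, compound 1 thus stands at the edge of what this assay reports, and the one further value shown is also a limit.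

Compound 3 `O=C1N(Cc2ccccc2Cl)c2cccn2S(=O)(=O)N1Cc1cccc(F)c1` has not been measured. Its change from compound 1 is chloro in place of cyano on an aromatic carbon, cyano leaving and chloro entering on an aromatic carbon of a six-membered aromatic ring of carbon only, ortho to a large group. For the measured compounds named here, the single measured step, a halogen swap on the other benzyl group, could not be sized, so no step size can be taken from it. With both measured compounds at limits, compound 3 is expected to show no step beyond the scatter in this assay, that is an at least 1.0-fold lower number from compound 1 to compound 3 (0.00 log units; that floor lies within the scatter). Compound 3 is estimated at 300000 nM, within 100000 nM to 1000000 nM, most likely again reported only as a limit.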

Compound 3, half-maximal cytotoxic concentration: 231000 nM
Estimate against measurement, compound 3: 1.3-fold (0.11 log units) above, and the stated range covers the measured number.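

Compound 3 is the first compound shown with a plain number in this assay (231000 nM), so the change from 2-cyanobenzyl to 2-chlorobenzyl yields a step that can be read in part, whereas the step from compound 1 to compound 2 cannot be read at all. The exchange of cyano for chloro on this aromatic carbon gives an at least 1.3-fold lower number from compound 1 to compound 3 (0.12 log units; that floor lies within the scatter), so a real shift at this position is not established, although the true step may be larger than this floor. Only a floor can be given, because compound 1 reads as a limit and not as a number: the limit of > 305000 nM in this assay, at which 1 of the 3 values shown sits.

Going by these compounds, whether an amine, a methoxy group or a carboxylic acid on this aromatic carbon would give a step beyond the scatter remains open. Also open, on these data alone, is whether the same exchange of cyano for chloro would read the same way on the core of compound 2, which carries chloro in place of fluoro on the other benzyl group.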